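Furan-2-ylmethyl amide in the quinoline acid series

The source may hold more compounds than are shown below. What is called first, only, known or untested is meant among the compounds shown, and "the series" means these compounds.

Three amides of the shared core have numbers in a physicochemical assay for lipophilicity, using the shake flask method, in phosphate buffer, measured as octanol-water partition, at pH 7.4; a lower number here means a more polar compound, a higher number a more lipophilic compound. Compound 1 `COc1cc(-c2cc(C(=O)O)c3ccccc3n2)ccc1OCC(=O)Nc1ccc(F)cc1` gives 1.1 in this assay. Compound 2 `COc1cc(-c2cc(C(=O)O)c3ccccc3n2)ccc1OCC(=O)Nc1ccccc1Cl` gives 1.6, and the step of a number 0.50 log units higher from compound 1 to compound 2 (beyond the scatter) is the only one among the three that clears the scatter. Compound 3 `COc1cc(-c2cc(C(=O)O)c3ccccc3n2)ccc1OCC(=O)Nc1ccccc1C(F)(F)F` gives 1.3; its number sits within the scatter of both neighbours, as the steps of a number 0.20 log units higher from compound 1 to compound 3 (within the scatter) and a number 0.30 log units lower from compound 2 to compound 3 (within the scatter) show, so compound 3 is not separated from either compound 1 or compound 2 on these numbers.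

Compound 4 `COc1cc(-c2cc(C(=O)O)c3ccccc3n2)ccc1OCC(=O)NCc1ccco1` is not yet measured. Its difference from compound 3 is (furan-2-yl)methyl in place of 2-(trifluoromethyl)phenyl on an amide-type nitrogen. Among the measured compounds shown here, no measured step bears directly on this change: the three steps so far exchange one substituted phenyl for another on the amide nitrogen, and the largest of them is the step of a number 0.50 log units higher from compound 1 to compound 2 (beyond the scatter). The change to compound 4 removes the whole substituted phenyl, with its three fluorines, and puts in a smaller group carrying one hydrogen-bond acceptor. On that basis a step of a number 0.80 log units lower from compound 3 to compound 4 (beyond the scatter) in this assay is expected, downward, larger than any of the measured steps. Compound 4 is estimated at 0.5, within -0.2 to 1.1.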

Compound 4, distribution coefficient: -0.3
Beside the measured number, compound 4's estimate is 0.80 log units above it; measured number outside the range, below it.
By their numbers in this assay, from the lowest: compound 4; then compounds 1, 3 and 2 (each within the scatter of the next, the first and the last beyond it).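

At the amide-type nitrogen, (furan-2-yl)methyl moves the number in this assay much further than any exchange among the substituted phenyls, with a number 1.60 log units lower from compound 3 to compound 4 (beyond the scatter) and a number 1.90 log units lower from compound 2 to compound 4 (beyond the scatter) and also a number 1.40 log units lower from compound 1 to compound 4 (beyond the scatter) whichever phenyl it replaces. All three steps are large and beyond the scatter, so compound 4 has the lowest number of the four, while the widest step among the phenyl amides is a number 0.50 log units higher from compound 1 to compound 2 (beyond the scatter) and is only modest. This position therefore tolerates a far greater range in this read-out than the phenyl amides alone suggested, though nothing available accounts for the size of the drop.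

The change alters the ring and the connection to the nitrogen together, so the shares of the two remain unresolved; a benzyl group on the amide-type nitrogen, or furan-2-yl attached directly to it, would begin to separate them. From the compounds shown here alone, how an open chain such as butyl, or a chain ending in an amine, would place itself relative to compound 4 in this assay also remains open.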